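This account rests on a few compounds, and the source may have more. Where it says the series, first, only, none or still open, it means among the compounds named here.

Three quinone-like compounds built on closely related cores were tested in a functional assay on HeLa cells (Homo sapiens) for cytotoxicity; on this read-out lower numbers stand for stronger inhibition and higher numbers for weaker inhibition. Compound 1, with the structure `CCOC1=CC(=O)c2ccccc2C1=O`, gives 23800 nM in this assay. Compound 2, `CS(=O)(=O)OC1=CC(=O)c2ccccc2C1=O`, carries a single change relative to compound 1, (methylsulfonyl in place of ethyl on an oxygen on an unsaturated carbon), and in this assay compound 2 gives 7610 nM. That change produced a 3.1-fold lower number from compound 1 to compound 2 (0.50 log units; beyond the scatter).

Compound 3, `CCOc1ccc2c(c1)C(=O)C=CC2=O`, has the same atoms as compound 1 but joined differently; the difference between the two cores is not broken down here. In this assay compound 3 gives 25100 nM, which sits within the scatter of compound 1 and is well separated from compound 2.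

Compound 4, `CS(=O)(=O)Oc1ccc2c(c1)C(=O)C=CC2=O`, has not yet been measured. It stands to compound 3 as compound 2 stands to compound 1: methylsulfonyl in place of ethyl on an oxygen on an aromatic ring. The surroundings are not identical, though. In compound 1 the oxygen sits on an unsaturated carbon whose other neighbours are a double-bonded ring carbon, whereas in compound 3 the oxygen sits on an aromatic ring whose other neighbours are an aromatic carbon. It is therefore the same kind of change rather than the same change.

Among the measured compounds shown here, because the only comparable example, a 3.1-fold lower number from compound 1 to compound 2 (0.50 log units; beyond the scatter), lies beyond the scatter, a step of similar size is expected here, namely a 2.5-fold lower number from compound 3 to compound 4 (0.40 log units; beyond the scatter). On that basis compound 4 is estimated to give 10000 nM in this assay, with a plausible range from 4000 nM to 25000 nM.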

Compound 4, half-maximal inhibitory concentration: 17700 nM
Beside the measured number, compound 4's estimate is 1.8-fold (0.25 log units) below it, within the range that was stated.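

Replacing ethyl with methylsulfonyl on the oxygen on the aromatic ring gives, in this assay, a 1.4-fold lower number from compound 3 to compound 4 (0.15 log units; within the scatter), so on this core the step cannot be told apart from the ordinary spread of repeated measurements, whereas on the core of compound 1 the same kind of change gave a 3.1-fold lower number from compound 1 to compound 2 (0.50 log units; beyond the scatter). Among the compounds shown here, at first sight the two steps look different in size, yet the gap between them is no larger than two such steps could show by chance: the same change on two cores in this assay, a 3.1-fold lower number (0.50 log units; beyond the scatter) from compound 1 to compound 2 and a 1.4-fold lower number (0.15 log units; within the scatter) from compound 3 to compound 4, 2.2-fold (0.34 log units) apart, within the scatter of two such steps The pair of steps therefore shows no measurable dependence of this change on the core, but it does not prove that the change carries over unaltered, since there is only one example on each core and only the step from compound 1 to compound 2 stands clear of the scatter.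

The compounds shown carry only ethyl and methylsulfonyl on this oxygen, leaving open how an acetyl group, a longer chain such as butyl, or an amine in place of the oxygen-linked group would behave on either core. Whether any such group would separate the two cores more clearly also remains an open question.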